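This account rests on a few compounds, and the source may have more. Where it says the series, first, only, none or still open, it means among the compounds named here.

Measured compounds:
compound 1, `COc1cccc(NC(=S)NC2CC(C)(C)Oc3ccc(Br)cc32)c1` — 87000 nM
compound 2, `O=[N+]([O-])c1ccc(NC(=S)NC2CCOc3ccc(Cl)cc32)cc1` — 12000 nM

In a functional assay on T98G cells (Homo sapiens) for inhibition, read by MTT assay, with a stated time of 72 h (a lower number here means a stronger inhibitor, a higher number a weaker inhibitor), compound 1 gives 87000 nM, the highest of the two numbers recorded. Its nearest neighbour is compound 2, which in this assay gives 12000 nM, a number well below that of compound 1 and a gap beyond the usual scatter of the assay. For the measured compounds named here, no step between compounds that differ in a single place is available, so the two values can only be set side by side; compounds 1 and 2 differ in several places at once.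

Compound 3, `CC1(C)CC(NC(=S)Nc2cccc(C#N)c2)c2cc(Br)ccc2O1`, has not yet been measured in this assay. It differs from compound 1 in one place: cyano in place of methoxy on an aromatic carbon. Going by the values given here, with no single-change step to lean on, the size of this step is uncertain; the account expects a modest move toward a lower number, of a size that may not exceed the scatter. The expected step is a 1.7-fold lower number from compound 1 to compound 3 (0.24 log units; within the scatter). Compound 3 is therefore estimated at 50000 nM, within a range from 15000 nM to 150000 nM.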

Compound 3, half-maximal inhibitory concentration: 9000 nM
Beside the measured number, compound 3's estimate is 5.6-fold (0.74 log units) above it; measured number outside the range, below it.
By their numbers in this assay, from the lowest: compounds 3 and 2 (each within the scatter of the next); then compound 1.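

In this assay there is now a step between compounds that differ in a single place: replacing 3-methoxyphenyl with 3-cyanophenyl gives a 9.7-fold lower number from compound 1 to compound 3 (0.99 log units; beyond the scatter) with the rest of the structure unchanged. This shows that the aromatic carbon meta to a large group is sensitive to which group it carries, since methoxy and cyano have the same count of heavy atoms and of hydrogen-bond acceptors, and neither has a net charge, yet the step lies beyond the scatter. No accompanying measurement accounts for the size of this step.

The compounds shown leave open whether other groups at this place, such as a trifluoromethyl group, a chlorine atom or an amine, would follow cyano or methoxy, so this single step establishes no trend across substituents. Going by these compounds, it is also open whether the same exchange would give a step of similar size on a different core, such as the core of compound 2, since only the core of compound 1 has been tested with both groups.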